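Solubility of the 3-(trifluoromethyl)benzyl and 4-(trifluoromethyl)benzyl isomers

The source may hold more compounds than are shown below. What is called first, only, known or untested is meant among the compounds shown, and "the series" means these compounds.

Compound 1, `O=C(CN1CCCC(c2ccccc2)(c2ccccc2)C1=O)N1CCN(Cc2cccc(Cl)c2)CC1` — < 25000 nM
Compound 2, `O=C(CN1CCCC(c2ccccc2)(c2ccccc2)C1=O)N1CCN(Cc2cccc(C(F)(F)F)c2)CC1` — < 25000 nM

In a physicochemical assay for solubility, at pH 7 (a higher number here means a more soluble compound, a lower number a less soluble compound), compound 1 gives < 25000 nM, which is a limit of the assay and not a number. Compound 2 in this assay gives < 25000 nM, again a limit. The step that the two limits leave unreadable from compound 1 to compound 2 is therefore unreadable, as both values sit at the limit of < 25000 nM in this assay, at which 2 of the 2 values shown sit. Compound 2 thus stands only at a limit; no number places it within the series.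

Compound 3, `O=C(CN1CCCC(c2ccccc2)(c2ccccc2)C1=O)N1CCN(Cc2ccc(C(F)(F)F)cc2)CC1`, differs from compound 2 by 4-(trifluoromethyl)phenyl in place of 3-(trifluoromethyl)phenyl on a saturated chain carbon bound to an amine nitrogen in a ring. No measured step bears on this change: the one step shown, a step that the two limits leave unreadable from compound 1 to compound 2, cannot be read in size or direction. The change from compound 2 to compound 3 is expected to give a step that the limit leaves unreadable from compound 2 to compound 3, nothing beyond the scatter. Compound 3 is therefore estimated at 10000 nM, within 3000 nM to 25000 nM, most likely again reported only as a limit.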

Compound 3, solubility: < 25000 nM
Compound 3 ended at the assay's limit (the forecaster's own chance of this, stated with the estimate: 80%); the middle value lies beyond the limit too.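

No new step can be read among compound 1, compound 2 and compound 3 in this assay, as each value is a limit of the assay and not a number: the limit of < 25000 nM in this assay, at which 3 of the 3 values shown sit.

Going by these compounds, whether the 3-(trifluoromethyl)benzyl and 4-(trifluoromethyl)benzyl isomers differ at all in this assay, and where any of the three compounds lies as a number, stays open.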